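Swapping a Naphthalene for a Propylurea: Solubility Outlook

A few compounds are considered here, and "the series" means these few. Any claim that something is new, unique, unknown or untested is made for them only; others in the source may bear on it.

Compound 1 `CN1CCC(C(=O)N2Cc3c(NC(=O)c4ccc5ccccc5c4)n[nH]c3C2(C)C)CC1`: 219000 nM
Compound 2 `CN1CCC(C(=O)Nc2n[nH]c3c2CN(C(=O)C(C)(C)C)C3(C)C)CC1`: > 225000 nM, a limit of the assay
Compound 3 `CCN1CCC(C(=O)N2Cc3c(NC(=O)c4ccc(F)cc4)n[nH]c3C2(C)C)CC1`: > 225000 nM, a limit of the assay

Of the compounds shown here, three have been measured in a physicochemical assay for solubility, at pH 7; a higher number here means a more soluble compound, a lower number a less soluble compound. For the measured compounds named here, compound 1 gives 219000 nM, the only actual number among them. For compound 2 the result > 225000 nM is a limit of the assay, not a number. For compound 3 the result > 225000 nM is likewise a limit. Compound 1 thus stands close to the limit of > 225000 nM in this assay, at which 2 of the 3 values shown sit.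

Compound 4 `CCCNC(=O)Nc1n[nH]c2c1CN(C(=O)C1CCN(C)CC1)C2(C)C` differs from compound 1 in one place: propylamino in place of naphthalen-2-yl on a carbonyl carbon. Going by the values given here, no measured pair shows this change, so the expected step is small, if anything upward, and within the scatter. The step of a 1.0-fold higher number from compound 1 to compound 4 (0.01 log units; within the scatter) is the estimated outcome. Compound 4 is expected to give about 225000 nM, with a range from 140000 nM to 320000 nM.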

Compound 4, solubility: > 225000 nM
Compound 4 ended at the assay's limit; the forecaster's own chance of this, stated with the estimate: 60%; the middle value lies on the limit itself.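

In this assay, this position on a carbonyl carbon now has a direct comparison: putting propylamino, with no ring, in place of naphthalen-2-yl, with its two aromatic rings, gives an at least 1.0-fold higher number from compound 1 to compound 4 (0.01 log units; that floor lies within the scatter). The result for compound 4 is a limit of the assay, not a number, so the step has a floor but no measured size, because most of the set now sits at that limit: the limit of > 225000 nM in this assay, at which 3 of the 4 values shown sit.

The compounds shown leave open how a longer chain, such as hexylamino, or a carboxylic acid on this carbonyl carbon would read. They also leave open whether either would give a number rather than a limit.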